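Swapping the Amide Aryl Ring for a Pyridyl Ring

This account rests on a few compounds, and the source may have more. Where it says the series, first, only, none or still open, it means among the compounds named here.

Compound 1 `O=C(Nc1cc(-c2ccccc2)nn1-c1ccccc1)c1ccc(F)cc1`: 30 nM
Compound 2 `O=C(Nc1cc(-c2ccccc2)nn1-c1ccccc1)c1ccccc1Cl`: 2500 nM

In an assay on CHO cells with metabotropic glutamate receptor 5 (Homo sapiens) as the target (a higher number here means that more compound is needed for the effect, a lower number that less compound is needed), compound 1 gives 30 nM, while compound 2 gives 2500 nM. Compound 2 therefore holds the higher of the two numbers, and the gap an 83-fold higher number from compound 1 to compound 2 (1.92 log units; beyond the scatter) shows that the ring on the carbonyl carbon has a large effect. Compound 3 `O=C(Nc1cc(-c2ccccc2)nn1-c1ccccc1)c1ccccn1` carries the change (pyridin-2-yl in place of 2-chlorophenyl on a carbonyl carbon). Within the data shown here, no measured step involves pyridin-2-yl, so only that one large step hints at how much a ring swap here can move the number. Compound 3 is expected to move back toward lower numbers, with a step of an 8.3-fold lower number from compound 2 to compound 3 (0.92 log units; beyond the scatter) estimated. The estimate for compound 3 is 300 nM, ranging from 40 nM to 2500 nM.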

Compound 3, half-maximal effective concentration: 290 nM
Compound 3: middle estimate off by 1.0-fold (0.01 log units), on the high side, and the stated range covers the measured number.
By their numbers in this assay, from the lowest: compound 1; then compound 3; then compound 2.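

In this assay, putting pyridin-2-yl on the carbonyl carbon gives an 8.6-fold lower number from compound 2 to compound 3 (0.94 log units; beyond the scatter), yet a 9.7-fold higher number from compound 1 to compound 3 (0.99 log units; beyond the scatter) remains. This position therefore gives a third clearly different number with a third ring, and compound 3 falls in the middle of the series. No measurement shown here explains these differences.

From the compounds shown here alone, the change removes chlorine and brings in a ring nitrogen at once, so the share of each stays open, and a plain phenyl ring would help separate them. Going by these compounds, how pyridin-3-yl or pyridin-4-yl would compare also remains open.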